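The compounds below may be only part of what the source reports. "The series", "measured", "known", "first", "only" and "open" are said of these compounds alone.

Of the compounds shown here, two have been read in an assay (strain Wistar) for inhibition of Hormone-sensitive lipase (Rattus norvegicus), read by spectrophotometry; on this read-out higher numbers stand for weaker inhibition and lower numbers for stronger inhibition. Compound 1 `CCc1c(C)n(C(=O)N2CCCCC2)oc1=O` gives 18 nM in this assay. Compound 2 `Cc1c(C(C)C)c(=O)on1C(=O)N(C)Cc1ccco1` gives 4 nM in this assay, the lower of the two numbers, and its gap to compound 1 lies beyond the usual scatter of repeated measurements. The next compound, compound 3 `Cc1c(C(C)C)c(=O)on1C(=O)N(C)c1ccccn1`, differs from compound 2 in a single place: pyridin-2-yl in place of (furan-2-yl)methyl on an amide-type nitrogen. Within the data shown here, no step between measured compounds covers an exchange of this kind, so the expectation rests on compound 2 alone and on the small size of the change. The expected step in this assay is a 2.0-fold higher number from compound 2 to compound 3 (0.30 log units; within the scatter), modest in size and of uncertain direction, leaning slightly toward a higher number. Compound 3 is estimated at 8 nM in this assay, with a range from 2 nM to 40 nM allowed for the uncertainty of a change without a measured precedent.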

Compound 3, half-maximal inhibitory concentration: 240 nM
Estimate against measurement, compound 3: 30-fold (1.48 log units) below; the measured number lies above the stated range.
By their numbers in this assay, from the lowest: compound 2; then compound 1; then compound 3.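

The amide-type nitrogen of this series does not accept every aromatic group equally in this assay: pyridin-2-yl in place of (furan-2-yl)methyl gives a 60-fold higher number from compound 2 to compound 3 (1.78 log units; beyond the scatter). The two groups carry the same number of heavy atoms, hydrogen-bond donors and hydrogen-bond acceptors, and neither has a net charge, so these counts do not separate them; the exchange instead alters ring size, hetero atom and the presence of the saturated chain carbon all at once. Nothing available on these compounds accounts for the size of the step.

Which of these three differences carries the step remains open. A pyridin-2-ylmethyl group on the same nitrogen would separate the effect of the ring from that of the chain carbon, and a furan-2-yl group would test the same question from the other side.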